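The source may hold more compounds than are shown below. What is called first, only, known or untested is meant among the compounds shown, and "the series" means these compounds.

Working notes on the series. Two compounds have numbers in an ADME assay on microsomes from liver (Homo sapiens) for metabolic stability, with a stated time of 30 min (a higher number here means that more of the compound is left, a lower number that less of the compound is left), so far. Compound 1, `C[C@H](Nc1ccc(C#N)n(C)c1=O)c1cc2cc(Cl)c(O[C@H](C)c3ccccn3)cc2[nH]c1=O`, gives 70% in this assay. Compound 2, `N#Cc1ccc(NCc2cc3cc(Cl)ccc3[nH]c2=O)c(=O)[nH]1`, gives 100% in this assay. Compound 1 stands lowest of the two, and the nearest number, that of compound 2, lies higher by a margin beyond the scatter. Among the measured compounds shown here, no step between compounds differing in a single place has been measured, so the two numbers show only that compound 2 is left to a greater extent than compound 1 after the stated time.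

Compound 3, `C[C@H](Nc1ccc(C#N)n(C)c1=O)c1cc2cc(Cl)c(F)cc2[nH]c1=O`, is not yet measured in this assay. It differs from compound 1 in one place: fluoro in place of 1-(pyridin-2-yl)ethoxy on an aromatic carbon. A large group leaves and a single atom enters on the carbocyclic ring of the fused system.

For the measured compounds named here, with no measured single-place step to lean on, a modest rise is expected; the expected step is a number 15 percentage points higher from compound 1 to compound 3 (beyond the scatter), which would bring compound 3 toward the region where compound 2 stands. For compound 3 in this assay the estimate is 85%, with a range from 65% to 100%.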

Compound 3, percent of the compound remaining: 100%
Compound 3: the middle estimate sits 15 percentage points below what was measured; the measured number falls inside the stated range.
By their numbers in this assay, from the lowest: compound 1; then compounds 2 and 3 (each within the scatter of the next).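

Among the compounds shown here, this is the first single-place step: with fluoro in place of 1-(pyridin-2-yl)ethoxy on the aromatic carbon ortho to a chloro group, this assay shows a number 30 percentage points higher from compound 1 to compound 3 (beyond the scatter). The rest of compound 1 is kept in compound 3, so the lower number of compound 1 can now be tied to this one place rather than to the remainder of the structure, and that remainder is compatible with compound 3 giving 100%. Nothing available gives a measured reason for the step, so the change can be described but not explained.

The compounds shown leave open which part of the 1-(pyridin-2-yl)ethoxy group goes with the step, the pyridine ring, the branching methyl or the ether oxygen, and how a methoxy group or a benzyloxy group would stand at this place. They also leave open whether fluoro itself matters or whether a plain hydrogen or a second chloro group at this carbon would read the same in this assay.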